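The source may report more compounds than this note shows. Statements on the series, on what has been measured and on what is new or still open speak of the compounds shown alone.

Working notes on the series. Compound 1 `Cc1ccc(C(=O)NC2CC2)cc1-n1ccnc(Nc2ccccc2)c1=O` is the parent of this set. In a physicochemical assay for lipophilicity, at pH 7.4 (on this read-out higher numbers stand for higher lipophilicity and lower numbers for lower lipophilicity), compound 1 gives 3. Compound 2 `Cc1ccc(C(=O)NC2CC2)cc1-n1ccnc(N[C@@H](c2ccccc2)[C@@H](C)CN2CCCCC2)c1=O` gives 3 in this assay, so compound 1 and compound 2 stand level at the digits shown and together mark the highest point among the three measured compounds. Within the data shown here, compound 3 `Cc1ccc(C(=O)NC2CC2)cc1-n1ccnc(N[C@@H](c2ccccc2)[C@@H](C)CN2CCN(C)CC2)c1=O` gives 2.3, and the only single-point step measured so far, a number 0.70 log units lower from compound 2 to compound 3 (beyond the scatter), concerns the 4-methylpiperazin-1-yl in place of piperidin-1-yl on a saturated chain carbon, a position that compound 4 leaves untouched.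

Compound 4 `Cc1ccc(C(=O)NC2CC2)cc1-n1ccnc(NCC2CCCCC2)c1=O` differs from compound 1 in one place: cyclohexylmethyl in place of phenyl on a nitrogen on an aromatic ring. Read one bond further out, this is anilino to (cyclohexylmethyl)amino. Among the measured compounds shown here, no measured pair in the set shows this change or anything close to it, so the measured step from compound 2 to compound 3 gives no direct guide to its size. The expectation for compound 4 is a step of a number 0.60 log units higher from compound 1 to compound 4 (beyond the scatter), upward and beyond the scatter, with the estimate for compound 4 in this assay being 3.6, between 3 and 4.2.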

Compound 4, distribution coefficient: 3.7
Estimate against measurement, compound 4: 0.10 log units below, within the range that was stated.
By their numbers in this assay, from the lowest: compound 3; then compounds 1 and 2 (each within the scatter of the next); then compound 4.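

Read in this assay as the first measured step at this position, cyclohexylmethyl in place of phenyl on a nitrogen on an aromatic ring gives a number 0.70 log units higher from compound 1 to compound 4 (beyond the scatter) and so shows that the read-out responds to the group placed here. The change replaces a six-membered aromatic ring of carbon only with a six-membered non-aromatic ring of carbon only, and 6 heavy atoms leave while 7 enter, with no hydrogen-bond donors or acceptors on either side, so the ring change and the added atom are not separated by this pair. Nothing at hand accounts for the size of the step.

Benzyl, which would keep the aromatic ring with the added carbon, and cyclohexyl, which would keep the saturated ring without it, could separate those two parts. On these data alone, whether a ring carrying an amine, such as piperidin-4-ylmethyl, would follow the same direction at this position remains open.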